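Dimethoxy extension of the indane headgroup in the arylpiperazine series

This account rests on a few compounds, and the source may have more. Where it says the series, first, only, none or still open, it means among the compounds named here.

The shared core of this small set is a benzodioxane-bearing piperazine linked by a short chain to a fused bicyclic carbon ring. Compound 1 `COc1ccc2c(c1)C(CCN1CCN(c3cccc4c3OCCO4)CC1)C2` carries a single methoxy group on the aromatic ring of that bicycle. In a functional assay on the whole organism for agonist activity, with Rattus norvegicus as the target (a lower number here means that less compound is needed, a higher number that more compound is needed for the effect), compound 1 gives 10 mg/kg, the lowest of the two numbers measured; compound 2 `Clc1cccc2c1CC2CN1CCN(c2cccc3c2OCCO3)CC1`, with a chlorine on the same ring and a shorter chain, gives 40 mg/kg, a step beyond the scatter. Compound 3 `c1ccc2c(c1)CCC2CCN1CCN(c2cccc3c2OCCO3)CC1`, with no substituent on that ring, reaches only (the limit of > 40 mg/kg in this assay, at which 1 of the 3 values shown sits), so for compound 3 the result > 40 mg/kg is a limit of this assay and not a number.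

Compound 4 `COc1cc2c(cc1OC)C(CCN1CCN(c3cccc4c3OCCO4)CC1)C2` differs from compound 1 by methoxy in place of hydrogen on an aromatic carbon. For the measured compounds named here, no measured pair in this set differs by a second methoxy, so the step in this assay is expected to be small, either direction, and likely within the scatter. Compound 4 is estimated at 15 mg/kg, with a range from 4 mg/kg to 60 mg/kg, meaning an expected step of a 1.5-fold higher number from compound 1 to compound 4 (0.18 log units; within the scatter).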

Compound 4, minimum effective dose: > 40 mg/kg
Compound 4 gave a limit, no number; the forecaster's own chance of this, stated with the estimate: 20%; middle value at least 2.6-fold (0.42 log units) from the limit.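

In this assay, methoxy in place of hydrogen on an aromatic carbon, ortho to a methoxy group, brings an at least 4.0-fold higher number from compound 1 to compound 4 (0.60 log units; beyond the scatter). For the compounds shown here, this is the first step that can be read at a single place: the earlier compounds differ from one another in more than one place, so none of them isolated a change on this ring. The value for compound 4 is a limit of the assay and not a number: the limit of > 40 mg/kg in this assay, at which 2 of the 4 values shown sit.

Going by these compounds, the full size of the step stays open, since only its lower bound can be read. Also open, on these data alone, is whether this step is specific to methoxy or would also follow from another group at the same carbon, such as fluorine, hydroxyl or methyl.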